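A Bromine Added to the Phenyl Ring of Compound 1

The compounds below may be only part of what the source reports. "The series", "measured", "known", "first", "only" and "open" are said of these compounds alone.

Among the measured compounds shown here, in a functional assay on brain for inhibition of Norepinephrine transporter (Rattus norvegicus) (on this read-out higher numbers stand for weaker inhibition and lower numbers for stronger inhibition), compound 1 (`CN(C)C/C=C(/c1ccccc1)c1cccnc1`) gives 27000 nM, the only plain number among the two values shown. Compound 2 (`Cc1ccc(/C(=C/CN(C)C)c2cccnc2)cc1`) reaches only a limit of the assay, > 29000 nM. For the measured compounds named here, the single measured step, an at least 1.0-fold higher number from compound 1 to compound 2 (0.03 log units; that floor lies within the scatter), concerns a methyl in place of hydrogen on an aromatic carbon, and its size is bounded by the limit of > 29000 nM in this assay, at which 1 of the 2 values shown sits. Compound 3 (`CN(C)C/C=C(\c1cccnc1)c1ccccc1Br`) differs from compound 1 by bromo in place of hydrogen on an aromatic carbon. Going by the values given here, no measured step involves a bromo group, so no shift beyond the scatter is expected for compound 3 in this assay. Compound 3 is therefore estimated at 30000 nM, within 10000 nM to 90000 nM. The expected step, a 1.1-fold higher number from compound 1 to compound 3 (0.05 log units; within the scatter), is small.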

Compound 3, half-maximal inhibitory concentration: 2200 nM
Compound 3: the middle estimate sits 14-fold (1.13 log units) above what was measured, outside the stated range (below it).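

A single bromo on an aromatic carbon, ortho to a large group, gives a 12-fold lower number from compound 1 to compound 3 (1.09 log units; beyond the scatter) in this assay and is the first step shown that lies beyond the scatter. Substitution on this ring can therefore change the number clearly. The methyl step could not show this, because compound 2 ends at a limit of the assay: the limit of > 29000 nM in this assay, at which 1 of the 3 values shown sits.

As far as these compounds go, whether other groups in the same place, such as chloro or an amine, give a shift of this size stays open. So does whether bromine or its place matters more.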